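Isopropoxy in place of hydrogen on compound 3

This account rests on a few compounds, and the source may have more. Where it says the series, first, only, none or still open, it means among the compounds named here.

Measured so far in a functional assay on HL-60 cells (Homo sapiens) for antiproliferative activity, read by MTT assay, with a stated time of 72 h; on this read-out higher numbers stand for weaker inhibition and lower numbers for stronger inhibition:
- compound 1 `COc1cc(-n2ncnc2-c2ccc(C)cc2)cc(OC)c1OC`: 90 nM
- compound 2 `COc1cc(-n2ncnc2-c2ccc(OC(F)(F)F)cc2)cc(OC)c1OC`: > 10000 nM, a limit
- compound 3 `COc1cc(-n2ncnc2-c2ccccc2)cc(OC)c1OC`: > 10000 nM, a limit

Compound 3 has no number of its own, only the limit > 10000 nM. Among the compounds with values here, the series so far is marked by the limit of > 10000 nM in this assay, at which 2 of the 3 values shown sit.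

The change to compound 4 `COc1cc(-n2ncnc2-c2ccc(OC(C)C)cc2)cc(OC)c1OC` is isopropoxy in place of hydrogen on an aromatic carbon.

Within the data shown here, three measured steps bear on it. Removing methyl gives an at least 110-fold higher number from compound 1 to compound 3 (2.04 log units; beyond the scatter), and trifluoromethoxy in place of methyl gives an at least 110-fold higher number from compound 1 to compound 2 (2.04 log units; beyond the scatter). Both are large. Between the two limits lies a step that the two limits leave unreadable from compound 2 to compound 3, which says nothing on size. A group at this place can therefore matter greatly in this assay, yet a group does not always bring a gain. Isopropoxy shares its oxygen link with compound 2, not with compound 1, so only a partial recovery is expected, toward lower numbers, and a result at the limit remains possible.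

The expected step is an at least 5.0-fold lower number from compound 3 to compound 4 (0.69 log units; beyond the scatter). For compound 4 the estimated value is 2000 nM, with an expected range of 150 nM to 10000 nM.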

Compound 4, half-maximal inhibitory concentration: 700 nM
Compound 4: middle estimate off by 2.9-fold (0.46 log units), on the high side; the range from low to high includes it.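

In this assay, the oxygen link alone does not fix the result at this place on the six-membered aromatic ring: isopropoxy gives an at least 14-fold lower number from compound 3 to compound 4 (1.15 log units; beyond the scatter), and isopropyl in place of trifluoromethyl on that oxygen gives an at least 14-fold lower number from compound 2 to compound 4 (1.15 log units; beyond the scatter). From the compounds shown here alone, both steps start from a limit and not from a number, so their full size is unknown, and the limit still marks the series: the limit of > 10000 nM in this assay, at which 2 of the 4 values shown sit. Against methyl, isopropoxy still shows a 7.8-fold higher number from compound 1 to compound 4 (0.89 log units; beyond the scatter) in this assay and so restores activity only in part.

The step between compound 2 and compound 3 cannot be read, both values being limits. Open too, going by these compounds, is where a methoxy group, a longer alkoxy chain or an amine at this place would fall relative to methyl and isopropoxy.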